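Phenethyl in place of 3-fluorophenyl on the sulfur

This account rests on a few compounds, and the source may have more. Where it says the series, first, only, none or still open, it means among the compounds named here.

Compound 3 `Nc1ccccc1NC(=O)/C=C/c1ccc(CSc2cccc(F)c2)cc1` gives 56.6% in a functional assay on A549 cells (Homo sapiens) for inhibition, read by CCK-8 assay, with a stated time of 72 h, tested at 8 uM (a lower number here means less inhibition of growth, a higher number more inhibition of growth at the concentration tested), the lowest of the three numbers shown. Its nearest neighbour is compound 2 `Nc1ccccc1NC(=O)/C=C/c1ccc(CSc2ccc(Cl)cc2)cc1` with 59.6%, and the two lie within the scatter of each other; the furthest is compound 1 `COc1ccc(SCc2ccc(/C=C/C(=O)Nc3ccccc3N)cc2)cc1OC` with 80.6%, and the step of a number 24 percentage points lower from compound 1 to compound 3 (beyond the scatter) lies beyond the scatter. Compound 4 `Nc1ccccc1NC(=O)/C=C/c1ccc(CSCCc2ccccc2)cc1` has not been measured; it differs from compound 3 by phenethyl in place of 3-fluorophenyl on a sulfur. The measured steps all change the group on this same sulfur: a number 21 percentage points lower from compound 1 to compound 2 (beyond the scatter) and a number 24 percentage points lower from compound 1 to compound 3 (beyond the scatter) both replaced 3,4-dimethoxyphenyl by 4-chlorophenyl or 3-fluorophenyl, while a number 3 percentage points lower from compound 2 to compound 3 (within the scatter) stayed within the scatter. Among the measured compounds shown here, no measured step introduces phenethyl, so these steps bear only indirectly on compound 4. Two groups without methoxy gave similar numbers, compound 2 with 59.6% and compound 3 with 56.6%, and on that basis no step beyond the scatter is expected for a number 1.6 percentage points lower from compound 3 to compound 4 (within the scatter). Compound 4 is therefore estimated at 55%, with a range from 35% to 75%.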

Compound 4, percent growth inhibition at one concentration: 50.3%
Beside the measured number, compound 4's estimate is 4.7 percentage points above it; low and high end bracket the measured number.
By their numbers in this assay, from the lowest: compounds 4, 3 and 2 (each within the scatter of the next); then compound 1.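

In this assay, among the compounds shown here, phenethyl is the first group on this sulfur whose ring does not sit directly on the sulfur, and that change leaves the number within the scatter of both groups with a halogen: a number 6.3 percentage points lower from compound 3 to compound 4 (within the scatter) and a number 9.3 percentage points lower from compound 2 to compound 4 (within the scatter) are the two steps that show it. Against the 3,4-dimethoxyphenyl group the picture stays as before, since a number 30.3 percentage points lower from compound 1 to compound 4 (beyond the scatter) lies beyond the scatter, and among these four compounds only compound 1 stands apart. Nothing on hand explains these numbers.

From the compounds shown here alone, it remains open whether a single methoxy group on the phenyl ring would be enough to reach the level of compound 1. Also open, going by these compounds, is whether an amine, a carboxylic acid or a longer chain on the sulfur would move the number beyond the scatter.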